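Methyl for chloro: compound 3 to compound 4

The source may hold more compounds than are shown below. What is called first, only, known or untested is meant among the compounds shown, and "the series" means these compounds.

In a functional assay on HCT-116 cells (Homo sapiens) for cytotoxicity, read by MTT assay, with a stated time of 72 h (a higher number here means a weaker inhibitor, a lower number a stronger inhibitor), compound 1 `COc1ncc(-c2ccc3nc(NC(=O)N4CCCC4)nn3c2)cc1NS(=O)(=O)c1ccc(F)cc1` gives 1290 nM while compound 2 `CCN(CC)CCNC(=O)Nc1nc2ccc(-c3cnc(OC)c(NS(=O)(=O)c4ccc(F)cc4F)c3)cn2n1` gives 140 nM and compound 3 `CCN(CC)CCNC(=O)Nc1nc2ccc(-c3cnc(OC)c(NS(=O)(=O)c4ccc(Cl)cc4)c3)cn2n1` gives 120 nM on the same read-out. Compound 3 therefore stands level with compound 2 within the scatter, and both numbers lie well below that of compound 1.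

Compound 4 `CCN(CC)CCNC(=O)Nc1nc2ccc(-c3cnc(OC)c(NS(=O)(=O)c4ccc(C)cc4)c3)cn2n1` differs from compound 3 in one group only. The change is methyl in place of chloro on an aromatic carbon with methyl in place of chloro on an aromatic carbon, para to a large group. For the measured compounds named here, the one measured step at this group is a 1.2-fold lower number from compound 2 to compound 3 (0.07 log units; within the scatter) and it lies within the scatter. Going by the values given here, it is a single step with a different substituent pattern, and no measured compound carries the methyl group, so the evidence is thin. No step beyond the scatter is expected in this assay and no direction is favoured. The expected step is a 1.1-fold higher number from compound 3 to compound 4 (0.03 log units; within the scatter) as an estimate. Compound 4 is estimated at 130 nM with an expected range from 60 nM to 280 nM in this read-out.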

Compound 4, half-maximal inhibitory concentration: 170 nM
Compound 4: middle estimate off by 1.3-fold (0.12 log units), on the low side; low and high end bracket the measured number.
By their numbers in this assay, from the lowest: compounds 3, 2 and 4 (each within the scatter of the next); then compound 1.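

Methyl in place of chloro on this aromatic carbon, para to a large group, gives a 1.4-fold higher number from compound 3 to compound 4 (0.15 log units; within the scatter) in this assay, so this change does not separate the two groups at this position. On the sulfonyl sulfur, 4-methylphenyl in place of 2,4-difluorophenyl gives a 1.2-fold higher number from compound 2 to compound 4 (0.08 log units; within the scatter) and thus stands level as well, which means that 4-chlorophenyl, 4-methylphenyl and 2,4-difluorophenyl all remain within the scatter of one another in this series. Nothing shown accounts for why these numbers stay level.

The compounds shown leave open whether a carboxylic acid, an amine or a longer chain on this aromatic carbon would give a step beyond the scatter. Also open, on these data alone, is whether a methoxy group there would stay level with methyl and chloro.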